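The compounds below may be only part of what the source reports. "The series", "measured", "known", "first", "only" and "open" are said of these compounds alone.

Compound 3 `Cc1cc(C(=O)O)nn1Cc1cc(Br)ccc1OCc1ccc(F)cc1` gives 7.41 nM in an assay on CHO-K1 cells for displacement of a labelled ligand from prostaglandin E2 receptor EP1 subtype (Homo sapiens) (on this read-out higher numbers stand for weaker inhibition and lower numbers for stronger inhibition), the second highest of the three numbers, and compound 2 `Cc1cc(C(=O)O)nn1Cc1cc(Br)ccc1OCc1ccc(Cl)cc1` gives 8.71 nM; the two lie within the scatter of each other (a 1.2-fold lower number from compound 2 to compound 3 (0.07 log units; within the scatter)). Compound 1 `Cc1cc(C(=O)O)nn1Cc1cc(Br)ccc1OCc1ccc(Cl)cc1Cl` gives 0.132 nM, and the step of a 56-fold higher number from compound 1 to compound 3 (1.75 log units; beyond the scatter) is large. Compound 4 `Cc1cc(C(=O)O)nn1Cc1cc(Br)ccc1OCc1ccccc1Cl` differs from compound 3 by 2-chlorophenyl in place of 4-fluorophenyl on a saturated chain carbon bound to an oxygen on an aromatic ring. The step of a 66-fold higher number from compound 1 to compound 2 (1.82 log units; beyond the scatter) bears on this most directly, since the chloro that leaves there is the one that enters here, while the step from compound 2 to compound 3 shows the other ring substituent adds little. Compound 4 is therefore expected to move down beyond the scatter, a 9.3-fold lower number from compound 3 to compound 4 (0.97 log units; beyond the scatter), though less than the whole of that step. Compound 4 is estimated at 0.8 nM, range 0.15 nM to 4 nM.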

Compound 4, half-maximal inhibitory concentration: 3.16 nM
Estimate against measurement, compound 4: 4.0-fold (0.60 log units) below; the measured number falls inside the stated range.
By their numbers in this assay, from the lowest: compound 1; then compound 4; then compounds 3 and 2 (each within the scatter of the next).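

The 2-chlorophenyl group gives a modest gain over 4-fluorophenyl (a 2.3-fold lower number from compound 3 to compound 4 (0.37 log units; beyond the scatter)) and over 4-chlorophenyl (a 2.8-fold lower number from compound 2 to compound 4 (0.44 log units; beyond the scatter)), so the two single-chloro rings are not equivalent. Neither single chloro comes close to 2,4-dichlorophenyl, as the large step (a 24-fold higher number from compound 1 to compound 4 (1.38 log units; beyond the scatter)) shows for the 2-chlorophenyl ring. The two chloro groups together therefore give far more than either gives alone.

As far as these compounds go, whether this gain is specific to chloro remains open, and a 2-bromophenyl or 2-methylphenyl group would test it. Nothing at hand explains these steps.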